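Reversing One Stereocentre of Compound 2

The source may report more compounds than this note shows. Statements on the series, on what has been measured and on what is new or still open speak of the compounds shown alone.

In a functional assay (mitochondria) for inhibition, with Rattus norvegicus as the target (on this read-out higher numbers stand for weaker inhibition and lower numbers for stronger inhibition), compound 1 `Cc1nc2cc(OC[C@H](O)CN3CCN(CC(=O)Nc4c(C)cccc4C)C[C@@H]3C)ccc2s1` gives 200 nM and compound 2 `Cc1nc2cc(OC[C@H](O)CN3C(C)CN(CC(=O)Nc4c(C)cccc4C)CC3C)ccc2s1` gives 70 nM, the lower of the two numbers, with a gap beyond the usual scatter. Compound 3 `Cc1nc2cc(OC[C@@H](O)CN3C(C)CN(CC(=O)Nc4c(C)cccc4C)CC3C)ccc2s1` has the same atoms and bonds as compound 2: the two compounds have the same atoms and bonds; at least one stereo element is drawn with a configuration in one of them and without one in the other: 1 of 3 stereo elements differ; a stereocentre at a saturated chain carbon is drawn R in compound 2 and S in compound 3, a stereocentre at a saturated chain carbon is drawn R in compound 2 and S in compound 3. Within the data shown here, no measured pair shows what this reversal does in this assay. The expected change, a 1.7-fold higher number from compound 2 to compound 3 (0.23 log units; within the scatter), is small and towards weaker inhibition, and it may stay within the scatter. Compound 3 is estimated at 120 nM, with an expected range from 35 nM to 450 nM.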

Compound 3, half-maximal inhibitory concentration: 2500 nM
Compound 3: middle estimate off by 21-fold (1.32 log units), on the low side, outside the stated range (above it).
By their numbers in this assay, from the lowest: compound 2; then compound 1; then compound 3.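

In this assay, reversing one stereocentre at a saturated chain carbon gives a 36-fold higher number from compound 2 to compound 3 (1.55 log units; beyond the scatter), a large step with no change in atoms or bonds. Compound 1 and compound 2 gave no view of this reversal, which now shows that the drawn configuration at this carbon can decide how strong the inhibition is. One caution applies to this reading: the fact that one of compounds 2 and 3 is drawn with a defined configuration and the other without, at the place where they differ.

The compounds shown leave open whether the same reversal has a similar effect on compound 1. Also open, as far as these compounds go, is what a methoxy group in place of the chain hydroxyl would do in either configuration.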